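Glycinamide series: effect of the acyl group in the rotarod test

The source may hold more compounds than are shown below. What is called first, only, known or untested is meant among the compounds shown, and "the series" means these compounds.

Compound 1 `CN(C(=O)CNC(=O)CN)c1ccc(Cl)cc1C(=O)c1ccccc1Cl` gives 27.7 mg/kg in a functional assay on the whole organism with Mus musculus as the target, in the rotarod test; on this read-out higher numbers stand for an effect only at larger amounts of compound and lower numbers for an effect already at smaller amounts.
Compound 2 `CC(C)C(=O)NCC(=O)N(C)c1ccc(Cl)cc1C(=O)c1ccccc1Cl` gives > 100 mg/kg in this assay, a limit of the assay and not a number.
Compound 3 `CN(C(=O)CNC(=O)c1ccccc1)c1ccc(Cl)cc1C(=O)c1ccccc1Cl` gives > 100 mg/kg in this assay, again a limit of the assay and not a number.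

For the measured compounds named here, compound 3 therefore stands at the upper edge of what this assay reports, together with compound 2 (the limit of > 100 mg/kg in this assay, at which 2 of the 3 values shown sit); compound 1 is the only member with a measured number. The next compound, compound 4 `CCCCCCC(=O)NCC(=O)N(C)c1ccc(Cl)cc1C(=O)c1ccccc1Cl`, follows from compound 3 by the change (hexyl in place of phenyl on a carbonyl carbon).

Going by the values given here, two measured steps bear on this position on the carbonyl carbon: an at least 3.6-fold higher number from compound 1 to compound 2 (0.55 log units; beyond the scatter) and an at least 3.6-fold higher number from compound 1 to compound 3 (0.55 log units; beyond the scatter). Both show that removing the aminomethyl group from the carbonyl carbon pushes the dose past the limit, whether a branched alkyl or an aromatic group takes its place. The comparison between the two replacements is a step that the two limits leave unreadable from compound 2 to compound 3, so no ordering between isopropyl and phenyl can be read. Compound 4 carries an alkyl group at this position, as compound 2 does, and no aminomethyl group, so it is expected to stay at the limit, with the estimated step being a step that the limit leaves unreadable from compound 3 to compound 4, not beyond the scatter in either direction. For compound 4 the estimate in this assay is 150 mg/kg, within a range from 60 mg/kg to 400 mg/kg.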

Compound 4, dose for half-maximal effect: 70 mg/kg
Compound 4: middle estimate off by 2.1-fold (0.33 log units), on the high side, within the range that was stated.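

In this assay, for the compounds shown here, compound 4 is the only member without an aminomethyl group on the carbonyl carbon that gives a number and not a limit, so a measurable dose on this read-out does not depend on that group. Against the two members at the limit, the hexyl compound shows an at least 1.4-fold lower number from compound 3 to compound 4 (0.15 log units; that floor lies within the scatter) and an at least 1.4-fold lower number from compound 2 to compound 4 (0.15 log units; that floor lies within the scatter), and neither floor establishes a real gap from phenyl or isopropyl, while a 2.5-fold higher number from compound 1 to compound 4 (0.40 log units; beyond the scatter) leaves the aminomethyl member with the lowest number among the compounds shown. Compounds 2 and 3 remain limits and not numbers: the limit of > 100 mg/kg in this assay, at which 2 of the 4 values shown sit.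

The compounds shown leave open how far the true values of compound 2 and compound 3 lie from that of compound 4, and therefore whether hexyl differs from isopropyl or phenyl at all. They also leave open how an octyl chain would read at this carbonyl carbon, and whether a hexyl chain ending in an amine or a carboxylic acid would stay with compound 4 or move towards compound 1.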